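A few compounds are considered here, and "the series" means these few. Any claim that something is new, unique, unknown or untested is made for them only; others in the source may bear on it.

Two related compounds have been measured in an ADME assay on HS27 cells (Homo sapiens) for antiproliferative activity, read by MTT assay, with a stated time of 24 h; a higher number here means a weaker inhibitor, a lower number a stronger inhibitor. Compound 1, `CC(=O)Nc1ncnc2c1ccn2-c1ccc(NC(=O)Nc2ccc(Cl)c(C(F)(F)F)c2)cc1`, gives only a limit of the assay in this assay: > 10000 nM. Compound 2, `O=C(Nc1ccc(-n2ccc3c(NC(=O)c4ccccc4)ncnc32)cc1)Nc1ccc(Cl)c(C(F)(F)F)c1`, gives 6000 nM in this assay, and this is the only actual number shown. Within the data shown here, the one measured step, an at least 1.6-fold lower number from compound 1 to compound 2 (0.22 log units; that floor lies within the scatter), comes from putting a phenyl in place of a methyl on a carbonyl carbon, and its size rests on (the limit of > 10000 nM in this assay, at which 1 of the 2 values shown sits).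

Compound 3, `O=C(Nc1ccc(-n2ccc3c(NC(=O)c4ccccc4)ncnc32)cc1)c1cccc(C(F)(F)F)c1`, has not been measured. It differs from compound 2 in one place: 3-(trifluoromethyl)phenyl in place of (4-chloro-3-(trifluoromethyl)phenyl)amino on a carbonyl carbon. Among the measured compounds shown here, no measured step touches this part of the molecule, so the measured change gives no direction for it. The expectation for compound 3 is therefore a number near that of compound 2, with a wide range, and an expected step of a 1.3-fold higher number from compound 2 to compound 3 (0.12 log units; within the scatter). Compound 3 is estimated at 8000 nM in this assay. Compound 3 is expected to fall between 2500 nM and 30000 nM.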

Compound 3, half-maximal inhibitory concentration: 5900 nM
Compound 3: the middle estimate sits 1.4-fold (0.13 log units) above what was measured, within the range that was stated.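

In this assay, among these compounds, the step of a 1.0-fold lower number from compound 2 to compound 3 (0.01 log units; within the scatter) is the first reading at this position, a carbonyl carbon whose other neighbour is an amide-type nitrogen; the earlier step concerned a different carbonyl carbon, where phenyl replaced methyl. The change is not a small one on paper: the leaving group, (4-chloro-3-(trifluoromethyl)phenyl)amino, carries a nitrogen with a hydrogen-bond donor and a chlorine, while the entering 3-(trifluoromethyl)phenyl has neither, yet this step stays within the scatter, so in these two compounds the loss of both together leaves no readable mark on the number. Nothing in the data shown explains why this swap leaves the reading where it is.

From the compounds shown here alone, the nitrogen and the chlorine leave in a single change, so what each one does alone remains open. Also open, going by these compounds, is how this assay responds when the aromatic ring on this carbonyl carbon gives way to something quite different, such as a cyclohexyl ring, a simple amine or a longer chain ending in a carboxylic acid.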